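Removing the hydroxyl from a diaryl chain

The source may hold more compounds than are shown below. What is called first, only, known or untested is meant among the compounds shown, and "the series" means these compounds.

Three compounds share one core. In a functional assay on HeLa cells (Homo sapiens) for cytotoxicity, read by WST assay, with a stated time of 48 h (a higher number here means a weaker inhibitor, a lower number a stronger inhibitor), compound 1 `COc1cc(C(c2ccc(O)c(OC)c2)[C@@H](C)C(C)C)ccc1O` gives 19000 nM. Compound 2 `COc1ccc(C(c2ccc(OC)c(OC)c2)[C@@H](C)[C@H](C)CO)cc1OC` sits only at the assay limit of > 100000 nM in this assay. Compound 3 `COc1cc(C(c2ccc(O)c(OC)c2)[C@@H](CO)C(C)C)ccc1O` likewise reaches only the limit of > 100000 nM in this assay, which is the limit of > 100000 nM in this assay, at which 2 of the 3 values shown sit. Among the compounds with values here, the one measured step that bears on the next change is an at least 5.2-fold higher number from compound 1 to compound 3 (0.72 log units; beyond the scatter). Compound 4 `COc1cc(C(c2ccc(O)c(OC)c2)[C@H](C)[C@@H](C)CF)ccc1O` differs from compound 3 by 2-(fluoromethyl)-1-methylpropyl in place of 1-(hydroxymethyl)-2-methylpropyl on a saturated chain carbon bound to two aromatic carbons. The hydroxy that weakened compound 1 on the way to compound 3 leaves again, so a step downward, roughly the reverse of that measured step, is expected, with the fluoromethyl an unknown. The estimated step is an at least 3.3-fold lower number from compound 3 to compound 4 (0.52 log units; beyond the scatter). Compound 4 is therefore expected to give about 30000 nM, between 8000 nM and 100000 nM.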

Compound 4, half-maximal inhibitory concentration: 34000 nM
Compound 4: middle estimate off by 1.1-fold (0.05 log units), on the low side; low and high end bracket the measured number.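

In this assay, the exchange on a saturated chain carbon bound to two aromatic carbons gives an at least 2.9-fold lower number from compound 3 to compound 4 (0.46 log units; beyond the scatter), so a chain without the hydroxy again reads below the limit. Within the data shown here, the fluoromethyl chain also gives a 1.8-fold higher number from compound 1 to compound 4 (0.25 log units; within the scatter), which places compound 4 within the scatter of compound 1, a comparison the earlier compounds could not offer. The first step is only a bound, as the value of compound 3 is a limit: the limit of > 100000 nM in this assay, at which 2 of the 4 values shown sit.

The compounds shown leave open whether the fluorine itself matters, as the chain's arrangement and stereocentres differ too. On these data alone, how an amine or a carboxylic acid at the chain end would read also stays open.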